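Two limits and a swapped sulfur link

This account rests on a few compounds, and the source may have more. Where it says the series, first, only, none or still open, it means among the compounds named here.

Compound 1 `Cc1nc(C)c([C@H](OC(C)(C)C)C(=O)O)c(N2CCC(C)(C)CC2)c1-c1ccc(OCCc2cc(F)ccc2F)cc1`: >= 33500 nM, a limit
Compound 2 `Cc1nc(C)c([C@H](OC(C)(C)C)C(=O)O)c(N2CCC(C)(C)CC2)c1-c1ccc(OCCCc2ccc(F)cc2)cc1`: >= 32000 nM, a limit

Both entries come from a toxicity assay on MT2 cells (Homo sapiens) for cytotoxicity, read by XTT assay, with a stated time of 4 days; on this read-out higher numbers stand for lower toxicity in this test and lower numbers for higher toxicity in this test. Compound 2 stands only at >= 32000 nM, which is a limit and not a number. Going by the values given here, the one other value shown, that of compound 1, is likewise a limit.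

Compound 3 `Cc1nc(C)c([C@H](OC(C)(C)C)C(=O)O)c(N2CCC(C)(C)CC2)c1-c1ccc(SCCc2ccc(F)cc2)cc1` has not yet been measured. It carries (2-(4-fluorophenyl)ethyl)sulfanyl in place of 3-(4-fluorophenyl)propoxy on an aromatic carbon, para to a large group ((2-(4-fluorophenyl)ethyl)sulfanyl in place of 3-(4-fluorophenyl)propoxy on an aromatic carbon).

Among the compounds with values here, only one measured step is at hand, and it changes a different part of the side chain: a step that the two limits leave unreadable from compound 1 to compound 2. Within the data shown here, it offers no size to carry over, and no measured step covers the new change. In this assay, no step beyond the usual scatter is therefore expected, and neither direction is favoured. The expected size of a number no higher from compound 2 to compound 3 (the limit leaves the size open) is accordingly small. For compound 3 the estimated value is 32000 nM, with an expected range from 15000 nM to 60000 nM.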

Compound 3, half-maximal cytotoxic concentration: >= 32000 nM
Compound 3 ended at the assay's limit; the forecaster's own chance of this, stated with the estimate: 70%; the middle value sits exactly at the limit.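

In this assay compound 3 stands at >= 32000 nM, which is a limit. Going by these compounds alone, no step among compound 1, compound 2 and compound 3 can be read: all three values are limits. The compounds shown leave open whether (2-(4-fluorophenyl)ethyl)sulfanyl and 3-(4-fluorophenyl)propoxy differ at all in this assay.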